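Moving the Thiophene Attachment in a Small Series

The compounds below may be only part of what the source reports. "The series", "measured", "known", "first", "only" and "open" are said of these compounds alone.

Within the data shown here, compound 2 `Cc1ccc(-c2cc(-c3ccc(Cl)o3)cc(-c3ccsc3)n2)cc1` holds the lowest of the two numbers so far in a functional assay on HeLa cells (Homo sapiens) for cytotoxicity, in the presence of a further agent that is not named here; a lower number here means a stronger inhibitor, a higher number a weaker inhibitor: compound 2 gives 16200 nM, while the related compound 1 `Clc1ccc(-c2cc(-c3ccc(Cl)o3)cc(-c3cccs3)n2)cc1` gives 21300 nM, a gap within the scatter, so the two cannot be told apart. Compound 3 `Cc1ccc(-c2cc(-c3ccc(Cl)o3)cc(-c3cccs3)n2)cc1` keeps every atom of compound 2, joined differently: thiophen-2-yl in place of thiophen-3-yl on an aromatic carbon. Among the measured compounds shown here, no measured pair shows this change on its own, so nothing beyond the scatter is expected in this assay. The expected step is a 1.1-fold higher number from compound 2 to compound 3 (0.05 log units; within the scatter). In this assay compound 3 is estimated to give 18000 nM, within a range of 8000 nM to 40000 nM.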

Compound 3, half-maximal inhibitory concentration: 16300 nM
The estimate for compound 3 lay 1.1-fold (0.04 log units) above the measured number; the range from low to high includes it.
By their numbers in this assay, from the lowest: compounds 2, 3 and 1 (each within the scatter of the next).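

In this assay thiophen-2-yl in place of thiophen-3-yl gives a 1.0-fold higher number from compound 2 to compound 3 (0.00 log units; within the scatter) and so leaves no readable mark at this position, next to the ring nitrogen. Methyl in place of chloro on an aromatic carbon gives a 1.3-fold lower number from compound 1 to compound 3 (0.12 log units; within the scatter) and likewise cannot be told apart from the scatter. Nothing measured here accounts for either result. With only the two thiophene attachments shown, it stays open whether a group of another kind at this position, such as an amine or a carboxylic acid, would move the number beyond the scatter.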